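The source may hold more compounds than are shown below. What is called first, only, known or untested is meant among the compounds shown, and "the series" means these compounds.

In a functional assay on MDA-MB-231 cells (Homo sapiens) for cytotoxicity, read by MTT assay, with a stated time of 72 h (on this read-out lower numbers stand for stronger inhibition and higher numbers for weaker inhibition), compound 3 `O=C1c2c[n+]([O-])c3ccccc3c2C(=O)c2c1c1ccccc1n2Cc1cn(CC(O)CO)nn1` gives 1290 nM. Compound 1 `O=C1c2c[n+]([O-])c3ccccc3c2C(=O)c2c1c1ccccc1n2Cc1cn(C[C@H](O)CO)nn1`, which has the same atoms and bonds, gives 1310 nM, and a 1.0-fold lower number from compound 1 to compound 3 (0.01 log units; within the scatter) cannot separate the two. Compound 2 `CC1(C)OCC(Cn2cc(Cn3c4c(c5ccccc53)C(=O)c3c[n+]([O-])c5ccccc5c3C4=O)nn2)O1` stands clearly lower at 230 nM. Compound 4 `CC1(C)O[C@@H](CO)[C@H](Cn2cc(Cn3c4c(c5ccccc53)C(=O)c3c[n+]([O-])c5ccccc5c3C4=O)nn2)O1` differs from compound 3 as follows: 5-(hydroxymethyl)-2,2-dimethyl-1,3-dioxolan-4-yl in place of 1,2-dihydroxyethyl on a saturated chain carbon bound to an aromatic nitrogen. The closest measured change is a 5.7-fold lower number from compound 1 to compound 2 (0.76 log units; beyond the scatter), where a dioxolane ring also replaces 1,2-dihydroxyethyl, and its reverse, a 5.6-fold higher number from compound 2 to compound 3 (0.75 log units; beyond the scatter), is of similar size. Compound 4 shares that ring but keeps a free hydroxymethyl, so only part of this gain is expected. The expected change is a 2.9-fold lower number from compound 3 to compound 4 (0.46 log units; beyond the scatter), towards stronger inhibition. For compound 4, the estimated value is 450 nM, with an expected range of 150 nM to 1300 nM.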

Compound 4, half-maximal inhibitory concentration: 680 nM
For compound 4 the middle estimate is 1.5-fold (0.18 log units) below the measured one, and the stated range covers the measured number.
By their numbers in this assay, from the lowest: compound 2; then compounds 4, 3 and 1 (each within the scatter of the next).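

Closing the 2,3-dihydroxypropyl chain into the ring while keeping a free hydroxymethyl gives no clear change, since a 1.9-fold lower number from compound 3 to compound 4 (0.28 log units; within the scatter) and a 1.9-fold lower number from compound 1 to compound 4 (0.28 log units; within the scatter) both stay within the scatter. The hydroxymethyl does matter on the ring, with a 3.0-fold higher number from compound 2 to compound 4 (0.47 log units; beyond the scatter), so the ring alone does not secure the lower number of compound 2. Nothing shown gives a reason for these steps.

From the compounds shown here alone, whether an amine or a carboxylic acid in place of the hydroxymethyl would behave like compound 4 stays open. So does the effect of reversing the two defined stereocentres of compound 4.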